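A Methyl on a Saturated Ring Carbon, Measured Twice

The compounds below may be only part of what the source reports. "The series", "measured", "known", "first", "only" and "open" are said of these compounds alone.

Compound 1 `CN1C(=O)CN(C2CCCC2)c2nc(Nc3ccc(N4CCCCC4)cc3)ncc21` gives 16900 nM. Compound 2 `CC1CCN(c2ccc(Nc3ncc4c(n3)N(C3CCCC3)CC(=O)N4C)cc2)CC1` is reported only as a limit of the assay, > 30000 nM. Compound 3 `CCN1C(=O)CN(C2CCCC2)c2nc(Nc3ccc(N4CCCCC4)cn3)ncc21` gives 17600 nM.

All three were tested in a functional assay on HeLa cells (Homo sapiens) for inhibition, read by MTT assay, with a stated time of 48 h; on this read-out higher numbers stand for weaker inhibition and lower numbers for stronger inhibition. Among the compounds with values here, the one change measured on a pair is methyl in place of hydrogen on a saturated ring carbon, and it made an at least 1.7-fold higher number from compound 1 to compound 2 (0.24 log units; that floor lies within the scatter). That step runs into the limit of this assay (the limit of > 30000 nM in this assay, at which 1 of the 3 values shown sits), so its true size is not known; it is only at least as large as stated. Compound 3 shares the change of methyl for hydrogen on a saturated ring carbon with compound 1 in neither direction; how the core of compound 3 differs from the core of compound 1 is not broken down here. In this assay compound 3 and compound 1 sit within the scatter of each other.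

Compound 4 `CCN1C(=O)CN(C2CCCC2)c2nc(Nc3ccc(N4CCC(C)CC4)cn3)ncc21` has not been measured. It differs from compound 3 by the same change methyl in place of hydrogen on a saturated ring carbon that separates compound 2 from compound 1. Resting on the step from compound 1 to compound 2 an at least 1.7-fold higher number from compound 1 to compound 2 (0.24 log units; that floor lies within the scatter), compound 4 is expected to show a weakening of a similar size, a 1.7-fold higher number from compound 3 to compound 4 (0.23 log units; within the scatter), with a real chance that this assay again reports only a limit. The estimate for compound 4 in this assay is 30000 nM, between 15000 nM and 60000 nM.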

Compound 4, half-maximal inhibitory concentration: > 30000 nM
Compound 4: no number, only a limit (the forecaster's own chance of this, stated with the estimate: 50%); the middle value lies on the limit itself.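

In this assay compound 4 is reported only as a limit, > 30000 nM. The change from piperidin-1-yl to 4-methylpiperidin-1-yl therefore reads as an at least 1.7-fold higher number from compound 3 to compound 4 (0.23 log units; that floor lies within the scatter), and the pattern on the two cores looks alike as far as it can be read, with a number for the compound without the methyl and only a limit for the compound with it, though this likeness rests on these four compounds alone: the same change on two cores in this assay, an at least 1.7-fold higher number (0.24 log units; that floor lies within the scatter) from compound 1 to compound 2 and an at least 1.7-fold higher number (0.23 log units; that floor lies within the scatter) from compound 3 to compound 4; the limit leaves it open whether they differ What the result does not show is how large the change truly is on either core, or whether the methyl costs the same on both, since neither compound carrying it gives a number that can be set against its partner: the limit of > 30000 nM in this assay, at which 2 of the 4 values shown sit.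

The compounds shown leave open what other groups would do on the same saturated ring carbon, three ring bonds from the ring nitrogen, for instance an amine or a carboxylic acid in place of the methyl, and whether any of them would return a number rather than a limit in this assay. They also leave open how a longer chain, such as ethyl or propyl, would read at that place on either core.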